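Fluoro for methyl on the central ring of compound 2

The source may report more compounds than this note shows. Statements on the series, on what has been measured and on what is new or still open speak of the compounds shown alone.

Measured so far:
Compound 1, `CCNc1cc(-c2ccc(NC(=O)Nc3ccc(C)cc3)cc2C)ccn1`, 47.5%
Compound 2, `CCNc1cc(-c2ccc(NC(=O)Nc3ccc(OC)cc3)cc2C)ccn1`, 45.8%
Compound 3, `CCNc1cc(-c2ccc(NC(=O)Nc3ccccc3Cl)cc2C)ccn1`, 49.2%

In an assay on isolated protein for inhibition of serine/threonine-protein kinase PLK1 (Homo sapiens), read by radiometric assay and 33P incorporation, with a stated time of 40 min, tested at 20 uM, in the presence of a further agent that is not named here (on this read-out lower numbers stand for less inhibition and higher numbers for more inhibition at the one concentration tested (going by the name of the read-out)), the three compounds give numbers that cannot be told apart: a number 1.7 percentage points lower from compound 1 to compound 2 (within the scatter), a number 1.7 percentage points higher from compound 1 to compound 3 (within the scatter), and a number 3.4 percentage points higher from compound 2 to compound 3 (within the scatter). Within the data shown here, compound 2 therefore stands alongside compound 1 and compound 3, with no step to either reaching beyond the scatter. All three changes so far concern the aryl group on the amide-type nitrogen.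

Compound 4, `CCNc1cc(-c2ccc(NC(=O)Nc3ccc(OC)cc3)cc2F)ccn1`, is not yet measured. Its change from compound 2 is fluoro in place of methyl on an aromatic carbon. Among the measured compounds shown here, no measured step touches this position; the three steps all lie at the far aryl group and are each within the scatter, so they give no measured guide to the present change. On this basis no step beyond the scatter is expected in this assay for compound 4, and a wide range is estimated. Compound 4 is expected to give 46%, between 28% and 62%. This estimate means an expected a number 0.2 percentage points higher from compound 2 to compound 4 (within the scatter).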

Compound 4, a percentage reported as inhibition, at one concentration (the size of the read-out at that concentration, not a potency): 47.1%
Compound 4: the middle estimate sits 1.1 percentage points below what was measured; measured number inside the range.
By their numbers in this assay, from the lowest: compounds 2, 4, 1 and 3 (each within the scatter of the next).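

In this assay, the exchange on the aromatic carbon ortho to a 2-(ethylamino)pyridin-4-yl group gives a number 1.3 percentage points higher from compound 2 to compound 4 (within the scatter). Among these compounds, this is the first measured step away from the far aryl group, and it shows that the methyl at this place can give way to fluoro with no change that can be told from the scatter. No measurement shown here bears on this result.

From the compounds shown here alone, whether an amine or a carboxylic acid at this same carbon, or a longer chain there, would move the number beyond the scatter remains open. Going by these compounds, because all four numbers come from a single concentration, it also remains open whether the compounds would differ in potency.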